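The source may report more compounds than this note shows. Statements on the series, on what has been measured and on what is new or still open speak of the compounds shown alone.

Compound 1 `N#Cc1ccc(-c2csc(N/N=C\c3cccnc3)n2)cc1` and compound 2 `C/C(=N/Nc1nc(-c2ccc(C#N)cc2)cs1)c1cccnc1` share a core with compound 3 `N#Cc1ccc(-c2csc(N/N=C\c3ccncc3)n2)cc1`, in which the pyridine ring is attached through a different carbon. In an in vitro assay on BTI-TN-5B1-4 cells for inhibition of Amine oxidase [flavin-containing] A (Homo sapiens), read by Amplex Red, with a stated time of 15 min, tested at 100 uM (on this read-out higher numbers stand for more inhibition at the one concentration tested (going by the name of the read-out) and lower numbers for less inhibition), compound 1 gives 40%, and compound 2 gives 40%. Compound 3 is reported in this assay as "not active" (no number reported), so no single number stands for it, and it can only be placed below the two compounds that do carry a number.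

Compound 4 `O=[N+]([O-])c1ccc(-c2csc(N/N=C\c3ccncc3)n2)cc1` is the unmeasured compound that follows from compound 3 by nitro in place of cyano on an aromatic carbon. Going by the values given here, no measured pair shows this change anywhere in the set, so its effect in this assay has to be guessed from compound 3 alone. Since compound 3 is reported as "not active" (no number reported) in this assay, the account expects no step beyond the scatter in this assay, with the small remaining chance of a rise toward the numbers seen for compound 1 and compound 2. On that basis compound 4 is estimated to give 15% in this assay, within a range from 0% to 45%, and there is a fair chance that it, too, is reported only as not active rather than with a number.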

Compound 4, a percentage reported as inhibition, at one concentration (the size of the read-out at that concentration, not a potency): "not active" (no number reported)
The entry for compound 4 holds no number; there is nothing to compare the estimate with.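

In this assay compound 3 gives "not active" (no number reported) and compound 4 gives "not active" (no number reported), so no step can be read between them. No supporting evidence bears on this result. The compounds shown leave open what nitro in place of cyano does where a number can be read, as on compound 1.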